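Removing one fluorine from a trifluorinated stilbene

The source may report more compounds than this note shows. Statements on the series, on what has been measured and on what is new or still open speak of the compounds shown alone.

Measured so far:
compound 1, `Fc1cccc(/C=C/c2ccccc2)c1` — 3100 nM
compound 2, `COc1cccc(/C=C/c2cccc(F)c2)c1` — 2300 nM
compound 3, `Fc1cccc(/C=C/c2ccc(F)c(F)c2)c1` — 5000 nM

In an assay on HepG2 cells for activation of nuclear factor erythroid 2-related factor 2 (Homo sapiens), read by a luciferase reporter, with a stated time of 5 h (a lower number here means that less compound is needed, a higher number that more compound is needed for the effect), compound 3 gives 5000 nM, the highest of the three numbers. Its neighbour is compound 1 at 3100 nM, a gap that stays within the scatter of repeated measurements; compound 2 at 2300 nM lies further off, beyond it. Compound 4, `Fc1cccc(/C=C/c2cccc(F)c2)c1`, is not yet measured. It differs from compound 3 in one place: hydrogen in place of fluoro on an aromatic carbon.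

Among the measured compounds shown here, only one single-point step has been measured, a 1.3-fold lower number from compound 1 to compound 2 (0.13 log units; within the scatter), and that exchange of methoxy for hydrogen on the other ring says little about taking a fluoro away. What remains is the comparison of compound 1 with compound 3: these two share the core and differ by two fluoro groups, and their numbers sit within the scatter of each other. Compound 4 sits between them in its count of fluoro groups, so in this assay the step of a 1.3-fold lower number from compound 3 to compound 4 (0.10 log units; within the scatter) is expected to stay within the scatter. The estimate for compound 4 is therefore 4000 nM, with a range from 2000 nM to 8000 nM.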

Compound 4, half-maximal effective concentration: 1000 nM
Compound 4: middle estimate off by 4.0-fold (0.60 log units), on the high side; the whole stated range lies above it.
By their numbers in this assay, from the lowest: compound 4; then compounds 2, 1 and 3 (each within the scatter of the next, the first and the last beyond it).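

In this assay, taking away this one fluoro gives a 5.0-fold lower number from compound 3 to compound 4 (0.70 log units; beyond the scatter), so a single atom at this place, ortho to a fluoro group and para to a group of 9 heavy atoms, can move the number beyond the scatter. Compound 4 also stands apart at the place where it differs from compound 1 and compound 2, with a 3.1-fold lower number from compound 1 to compound 4 (0.49 log units; beyond the scatter) and a 2.3-fold lower number from compound 2 to compound 4 (0.36 log units; beyond the scatter), so fluoro there goes with a lower number than either hydrogen or methoxy. Adding fluoro therefore has no single direction in these steps: fluoro in place of hydrogen lowers the number on the way to compound 4, while compound 3, which carries one more fluoro than compound 4, goes against that trend with a higher number.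

On these data alone, whether a chlorine atom, a hydroxyl group or an amine at the place of the lost fluoro would keep the lower number remains open. No measurement shown here accounts for why either place responds as it does.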